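A few compounds are considered here, and "the series" means these few. Any claim that something is new, unique, unknown or untested is made for them only; others in the source may bear on it.

In a functional assay on MCF7 cells (Homo sapiens) for inhibition, read by CCK-8 assay, with a stated time of 48 h (a higher number here means a weaker inhibitor of growth, a lower number a stronger inhibitor of growth), compound 1 `Cc1ccccc1Nc1nc(Nc2ccc(N3CCN(C)CC3)cc2)ncc1Cl` gives 20600 nM as its reading. Compound 2 `COc1ccccc1CNc1nc(Nc2ccc(N3CCN(C)CC3)cn2)ncc1Cl` stands at > 100000 nM as a limit of the assay, not a number. Compound 3 `CN1CCN(c2ccc(Nc3ncc(Cl)c(Nc4ccc(C(C)(C)C)cc4)n3)nc2)CC1` differs from compound 2 by 4-(tert-butyl)phenyl in place of 2-methoxybenzyl on a nitrogen on an aromatic ring. Going by the values given here, the expectation rests on compound 1 at 20600 nM as the only true number so far. A move toward stronger inhibition of growth in this assay is expected, with an at least 5.0-fold lower number from compound 2 to compound 3 (0.69 log units; beyond the scatter) as the estimated step. Compound 3 is estimated at 20000 nM within an expected range of 4000 nM to 100000 nM for now.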

Compound 3, concentration for 50% growth inhibition: 12600 nM
Beside the measured number, compound 3's estimate is 1.6-fold (0.20 log units) above it; the range from low to high includes it.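

In this assay, 4-(tert-butyl)phenyl in place of 2-methoxybenzyl on a nitrogen on an aromatic ring gives an at least 7.9-fold lower number from compound 2 to compound 3 (0.89 log units; beyond the scatter) in this one-place change. Going by these compounds alone, this is the first readable step, and it shows that this position bears on growth inhibition. Its size is only a bound, since compound 2 stands at a limit of the assay, not a number: the limit of > 100000 nM in this assay, at which 1 of the 3 values shown sits.

Open, going by these compounds, is whether the step belongs to the tert-butyl or to the change from benzyl to phenyl. Also open, on these data alone, is how a plain phenyl, an amine or a carboxylic acid would read at this position.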